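The compounds below may be only part of what the source reports. "The series", "measured", "known", "first", "only" and "open" are said of these compounds alone.

Compound 1 `CN(C)CC[C@H](CSc1ccccc1)Nc1ccc(S(=O)(=O)NC(=O)c2ccc(N3CCN(Cc4ccccc4-c4ccc(Cl)cc4)CC3)cc2)cc1C(F)(F)F` — in an assay on isolated protein for displacement of a labelled ligand from Bcl2-associated agonist of cell death (Homo sapiens), read by fluorescence polarization (a higher number here means a weaker inhibitor, a lower number a stronger inhibitor), compound 1 gives < 1 nM, which is a limit of the assay rather than a number.
Compound 2 `CN(C)CC[C@H](CSc1ccccc1)Nc1ccc(S(=O)(=O)NC(=O)c2ccc(N3CCN(CC4=C(c5ccc(Cl)cc5)CCOC4)CC3)cc2)cc1[N+](=O)[O-]` — in this assay compound 2 gives < 1 nM, which is also a limit, not a number.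

Both measured compounds therefore sit at the limit of < 1 nM in this assay, at which 2 of the 2 values shown sit, and compound 1 stands at that limit with no exact value known. Among the measured compounds shown here, no step between two measured compounds is available, so the only guide is the structure of compound 1 itself. Compound 3 `CN(C)CC[C@H](CSc1ccccc1)Nc1ccc(S(=O)(=O)NC(=O)c2ccc(N3CCN(Cc4ccccc4-c4ccc(Cl)cc4)CC3)cc2)cc1S(=O)(=O)C(F)(F)F` differs from compound 1 in a single place: (trifluoromethyl)sulfonyl in place of trifluoromethyl on an aromatic carbon. Given that compound 1 is already stronger than this assay can resolve, the step from compound 1 to compound 3 is expected to be a step that the limit leaves unreadable from compound 1 to compound 3, that is, no change beyond the usual scatter in either direction. Compound 3 is accordingly expected to give about 0.5 nM in this assay, most likely reported again as a limit, with a range from 0.1 nM to 2 nM.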

Compound 3, inhibition constant: < 1 nM
Compound 3 ended at the assay's limit; the forecaster's own chance of this, stated with the estimate: 80%; the middle value lies beyond the limit too.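

Among the compounds shown here, compound 1 and compound 3 both give only a limit rather than a number, so no step between them can be read: the limit of < 1 nM in this assay, at which 3 of the 3 values shown sit. The compounds shown leave open whether (trifluoromethyl)sulfonyl in place of trifluoromethyl changes the true strength in this assay at all, and in which direction.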